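This account rests on a few compounds, and the source may have more. Where it says the series, first, only, none or still open, it means among the compounds named here.

Of the compounds shown here, two have so far been measured in a functional assay on the whole organism with Rattus norvegicus as the target, read by paw edema, with a stated time of 3 h, at a dose of 100 mg/kg by the oral route; a higher number here means more inhibition at the dose given (going by the name of the read-out), a lower number less inhibition. Compound 1, `Cc1cccc(-c2nc3cc(O)ccc3[nH]2)n1`, gives 6% in this assay. Compound 2, `CCc1ccc(-c2nc3cc(O)ccc3[nH]2)nc1`, gives 25% in this assay, the higher of the two numbers; its gap to compound 1 lies beyond the usual scatter of such measurements. Compound 3, `CCc1ccc(-c2nc3cc(NC(C)=O)ccc3[nH]2)nc1`, has not yet been measured. It differs from compound 2 in a single place: acetamido in place of hydroxy on an aromatic carbon. For the measured compounds named here, no step between two measured compounds that differ in one place is known here, so nothing directly calibrates this change. A small step in this assay is expected, in either direction and probably not beyond the scatter, since compound 2 at 25% already sits at a modest level. Compound 3 is therefore expected to give about 20% in this assay, with a range from 0% to 45%. That expectation amounts to an estimated step of a number 5 percentage points lower from compound 2 to compound 3 (within the scatter).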

Compound 3, a percentage reported as inhibition, in the whole organism at one dose (the size of the read-out at that dose, not a potency): 5%
The estimate for compound 3 lay 15 percentage points above the measured number; measured number inside the range.
By their numbers in this assay, from the lowest: compounds 3 and 1 (each within the scatter of the next); then compound 2.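

In this assay, for the compounds shown here, putting acetamido in place of hydroxy on this aromatic carbon gives a number 20 percentage points lower from compound 2 to compound 3 (beyond the scatter), the first direct reading of a change at this position. With the rest of the structure held fixed, the group on this carbon clearly affects the result at the single dose tested, and the matching counts of hydrogen-bond donors and acceptors for the two groups did not keep the number level. No measurement available here accounts for this drop.

Going by these compounds, it remains open whether the whole acetamido group matters or only part of it, and an amine or a methoxy group on the same carbon would help to separate these possibilities. Also open, on these data alone, is whether the same swap would have a similar effect on a core carrying something other than ethyl, such as a longer chain.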